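The source may hold more compounds than are shown below. What is called first, only, known or untested is meant among the compounds shown, and "the series" means these compounds.

Of the compounds shown here, three on a shared core have numbers so far. In a functional assay on SK-OV-3 cells (Homo sapiens) for cytotoxicity (on this read-out lower numbers stand for stronger inhibition and higher numbers for weaker inhibition), compound 1 (`Cc1ccc(-c2cc3cc(C)ccc3c(O)n2)cc1`) gives 4900 nM and compound 2 (`COc1ccc(-c2cc3cc(C)ccc3c(N3CCN(C)CC3)n2)cc1`) gives 7940 nM while compound 3 (`Cc1ccc2c(N3CCN(C)CC3)nc(-c3ccc(Cl)cc3)cc2c1`) gives 5750 nM and so stands within the scatter of both others. Compound 4 (`Cc1ccc(-c2cc3cc(C)ccc3c(N3CCN(C)CC3)n2)cc1`) is still unmeasured. It differs from compound 3 by a single swap, methyl in place of chloro on an aromatic carbon, para to a large group (methyl in place of chloro on an aromatic carbon). Within the data shown here, one measured step bears on this, since it touches the same aromatic carbon, with chloro in place of methoxy. That step is small, at a 1.4-fold lower number from compound 2 to compound 3 (0.14 log units; within the scatter) and stays within the scatter. On that evidence, no step beyond the scatter is expected in this assay for the swap from chloro to methyl, and no direction can be called. The estimate amounts to a 1.0-fold higher number from compound 3 to compound 4 (0.02 log units; within the scatter) as an expected step inside the scatter. Compound 4 is estimated at 6000 nM with 3000 nM to 12000 nM as the expected span.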

Compound 4, half-maximal inhibitory concentration: 7080 nM
The estimate for compound 4 lay 1.2-fold (0.07 log units) below the measured number; the range from low to high includes it.
By their numbers in this assay, from the lowest: compounds 1, 3, 4 and 2 (each within the scatter of the next).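

In this assay, the change from 4-chlorophenyl to 4-methylphenyl (a 1.2-fold higher number from compound 3 to compound 4 (0.09 log units; within the scatter)) and the change from methoxy to methyl on the same aromatic carbon (a 1.1-fold lower number from compound 2 to compound 4 (0.05 log units; within the scatter)) both stay small, so methoxy, chloro and methyl now all lie within the scatter of one another at this position. Compound 4 also allows a comparison at a second place on the shared core, with the methyl group on the aromatic ring held fixed, and 4-methylpiperazin-1-yl in place of hydroxy (a 1.4-fold higher number from compound 1 to compound 4 (0.16 log units; within the scatter)) likewise produces no step beyond the scatter. No measurement at hand explains why these swaps leave the number so little changed.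

Going by these compounds, whether an amine or a carboxylic acid on this aromatic carbon would produce a step beyond the scatter remains open. Also open, on these data alone, is whether a longer chain in place of the methyl on the 4-methylpiperazin-1-yl group would do so.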